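From 3-chlorophenyl to 2,4,5-trichlorophenyl on compound 2

A few compounds are considered here, and "the series" means these few. Any claim that something is new, unique, unknown or untested is made for them only; others in the source may bear on it.

compound 1 `CC(C)(C)c1ccc(OCCCON2C(N)=NC(N)=NC23CCSCC3)cc1` gives 70 nM
compound 2 `NC1=NC2(CCSCC2)N(OCCCOc2cccc(Cl)c2)C(N)=N1` gives 90 nM
compound 3 `Cc1cc(C)cc(OCCCON2C(N)=NC(N)=NC23CCOCC3)c1` gives 680 nM

In a functional assay on HepG2 cells (Homo sapiens) for antiproliferative activity, read by MTT assay, with a stated time of 72 h (on this read-out lower numbers stand for stronger inhibition and higher numbers for weaker inhibition), compound 2 (90 nM) stands within the scatter of compound 1 (70 nM), while compound 3 (680 nM) has a higher number than compound 2, beyond the scatter. Compound 4 `NC1=NC2(CCSCC2)N(OCCCOc2cc(Cl)c(Cl)cc2Cl)C(N)=N1` carries 2,4,5-trichlorophenyl in place of 3-chlorophenyl on an oxygen on a saturated carbon. For the measured compounds named here, no measured pair shows this change directly. With compound 2 (90 nM) and compound 1 (70 nM) within the scatter of each other, no step beyond the scatter is expected in this assay, only a slight drift toward stronger inhibition. The estimated change is a 1.5-fold lower number from compound 2 to compound 4 (0.18 log units; within the scatter) and is expected to stay within the scatter. For compound 4 the expected value is 60 nM and the estimated range runs from 20 nM to 200 nM on this read-out.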

Compound 4, half-maximal inhibitory concentration: > 100000 nM
Compound 4 gave a limit, no number (the forecaster's own chance of this, stated with the estimate: 3%); middle value at least 1600-fold (3.22 log units) away from the limit.
By their numbers in this assay, from the lowest: compounds 1 and 2 (each within the scatter of the next); then compound 3. At a limit, above all of these: compound 4.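

For the compounds shown here, the earlier compounds offered no step in a single place; this is the first, and it shows that the group on this oxygen can decide the outcome in this assay. Replacing 3-chlorophenyl with 2,4,5-trichlorophenyl gives an at least 1100-fold higher number from compound 2 to compound 4 (3.04 log units; beyond the scatter). The reading for compound 4 is a limit of the assay, not a number: the limit of > 100000 nM in this assay, at which 1 of the 4 values shown sits.

The compounds shown leave open whether a dichlorophenyl group at this place would read close to compound 2 or to compound 4. They also leave open whether a phenyl ring carrying an amine or a carboxylic acid would retain activity.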